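The source may report more compounds than this note shows. Statements on the series, on what has been measured and on what is new or still open speak of the compounds shown alone.

Working notes on the series in a functional assay on MGC-803 cells (Homo sapiens) for antiproliferative activity, read by MTT assay, with a stated time of 72 h; on this read-out higher numbers stand for weaker inhibition and lower numbers for stronger inhibition. Compound 2 (`O=C(CNc1ccccc1)N[C@H]1CCOC1=O`) has no number on this read-out, and compound 2 stands at the limit > 64000 nM. Compound 1 (`CC(C)c1ccc(NCC(=O)N[C@H]2CCOC2=O)cc1`) is also only a limit, at > 64000 nM. Compound 3 (`O=C(CNc1ccccc1Cl)N[C@H]1CCOC1=O`) is likewise only a limit, at > 64000 nM.

The next structure is compound 4 (`O=C(CNc1ccc(Cl)cc1)N[C@H]1CCOC1=O`), with chloro in place of hydrogen on an aromatic carbon, para to a large group: chloro in place of hydrogen on an aromatic carbon.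

The closest measured change, also chloro in place of hydrogen on an aromatic carbon, is a step that the two limits leave unreadable from compound 2 to compound 3. The other measured change, hydrogen in place of isopropyl, is a step that the two limits leave unreadable from compound 1 to compound 2. Among the measured compounds shown here, neither gives a size to carry over, and the only evidence is the limit of > 64000 nM in this assay, at which 3 of the 3 values shown sit.

On that basis, no step beyond the scatter is expected in this assay, and no direction can be assigned. The estimated step is a step that the limit leaves unreadable from compound 2 to compound 4. For compound 4 the estimated value is 70000 nM, with an expected range of 35000 nM to 130000 nM.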

Compound 4, half-maximal inhibitory concentration: > 64000 nM
Compound 4 gave a limit, no number (the forecaster's own chance of this, stated with the estimate: 85%); the middle value is on the limit's open side.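

No new step can be read for compound 4 against compound 1 or compound 2 in this assay, because all of these compounds stand only as limits: the limit of > 64000 nM in this assay, at which 4 of the 4 values shown sit.

The compounds shown leave open whether any substituent on the aromatic ring changes inhibition, and in which direction.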